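This account rests on a few compounds, and the source may have more. Where it says the series, first, only, none or still open, it means among the compounds named here.

Measured compounds:
compound 1 `N#Cc1ccc(NC(=O)c2cc(F)ccc2O)cc1` gives 1420 nM in a functional assay on HL-60 cells (Homo sapiens) for cytotoxicity, read by luminescence and CellTiter-Glo, with a stated time of 3 days; on this read-out lower numbers stand for stronger inhibition and higher numbers for weaker inhibition.
compound 2 `O=C(Nc1ccc(C(F)(F)F)cc1)c1cc(F)ccc1O` gives 490 nM in this assay.
compound 3 `N#Cc1ccc(NC(=O)c2ccc3cccnc3c2O)cc1` gives 370 nM in this assay.

Compound 1 and compound 2 share a core and differ in one place: trifluoromethyl in place of cyano on an aromatic carbon. That change gave a 2.9-fold lower number from compound 1 to compound 2 (0.46 log units; beyond the scatter). Compound 3 sits on a different core, and the difference between the core of compound 1 and the core of compound 3 is not broken down here. Against compound 2, compound 3 lies within the scatter. Against compound 1, compound 3 gives a lower number, beyond the scatter.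

Compound 4 `O=C(Nc1ccc(C(F)(F)F)cc1)c1ccc2cccnc2c1O` has not been measured in this assay. It differs from compound 3 in one place: trifluoromethyl in place of cyano on an aromatic carbon. This is the same change as that from compound 1 to compound 2, here made on the core of compound 3, and the place is described in the same words for both pairs. Going by these compounds, the change has been measured only once, so whether it carries over to the second core is untested. For compound 4 a step of similar size is expected, a 2.6-fold lower number from compound 3 to compound 4 (0.42 log units; beyond the scatter), because the same change gave a 2.9-fold lower number from compound 1 to compound 2 (0.46 log units; beyond the scatter). Compound 4 is accordingly estimated at 140 nM, with a range from 50 nM to 400 nM.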

Compound 4, half-maximal inhibitory concentration: 680 nM
Beside the measured number, compound 4's estimate is 4.9-fold (0.69 log units) below it; the whole stated range lies below it.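

On the core of compound 3, trifluoromethyl in place of cyano gives a 1.8-fold higher number from compound 3 to compound 4 (0.26 log units; within the scatter) in this assay, so the two compounds cannot be told apart on this read-out. The change therefore does not carry over from the core of compound 1 to the core of compound 3 in these two pairs, and the two steps differ by more than the scatter: the same change on two cores in this assay, a 2.9-fold lower number (0.46 log units; beyond the scatter) from compound 1 to compound 2 and a 1.8-fold higher number (0.26 log units; within the scatter) from compound 3 to compound 4, 5.3-fold (0.73 log units) apart, beyond the scatter of two such steps. This shows that the effect of this change depends on the core in this series, but with a single pair on each core it does not show which part of the core is responsible, nor how any other replacement would transfer.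

The compounds shown leave open how an amine or a carboxylic acid in place of cyano on that aromatic carbon would behave on either core. They also leave open whether a methoxy group in place of the hydroxyl would alter the step on either core.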